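Isopropyl in Place of Carboxymethyl at the Side Chain

The source may hold more compounds than are shown below. What is called first, only, known or untested is meant among the compounds shown, and "the series" means these compounds.

Compound 1, `O=C(O)CC[C@H](NC(=O)CN(c1nc(Cl)nc2[nH]cnc12)C1CC1)C(=O)O`, was tested in a functional assay on the whole organism (Tail, strain ICR) with Mus musculus as the target, in the tail flick test, with a stated time of 60 min, at a dose of 25 umol/kg by the oral route (on this read-out higher numbers stand for a stronger effect at the one dose given and lower numbers for a weaker effect), where compound 1 gives 33.3%. Of the three numbers shown, this is the highest, but the other two lie within the usual scatter of it. Compound 2, `NC(=O)C[C@H](NC(=O)CN(c1ncnc2c1ncn2C1CCCCO1)C1CC1)C(=O)OCc1ccccc1`, gives 30.5% in this assay, and compound 3, `CC(C)(C)OC(=O)NCCCC[C@H](NC(=O)CN(c1ncnc2c1ncn2C1CCCCO1)C1CC1)C(=O)OCc1ccccc1`, gives 32.7%. For the measured compounds named here, the one measured step between them, a number 2.2 percentage points higher from compound 2 to compound 3 (within the scatter), swaps one side chain for another at the same place on the chain and stays within the scatter.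

The new compound 4, `CC(C)C[C@H](NC(=O)CN(c1nc(Cl)nc2[nH]cnc12)C1CC1)C(=O)O`, differs from compound 1 by isopropyl in place of carboxymethyl on a saturated chain carbon, two bonds along the chain from an amide-type nitrogen and a carbonyl carbon. Going by the values given here, the step from compound 2 to compound 3 is the only measured step that changes this side chain, and it was within the scatter, so no step beyond the scatter is expected here either. Compound 4 is therefore expected to give 32% in this assay, with a range from 20% to 44%. The expected step of a number 1.3 percentage points lower from compound 1 to compound 4 (within the scatter) is small.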

Compound 4, a percentage reported as activity, at one dose (the size of the read-out at that dose, not a potency): 36.4%
Compound 4: middle estimate off by 4.4 percentage points, on the low side, and the stated range covers the measured number.
By their numbers in this assay, from the lowest: compounds 2, 3, 1 and 4 (each within the scatter of the next).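

In this assay, exchanging the side chain at this place gives a number 3.1 percentage points higher from compound 1 to compound 4 (within the scatter), so on the core of compound 1 this change, too, stays within the scatter. The earlier step at this place, on the core of compound 2, did not remove a carboxylic acid; here carboxymethyl, with its hydrogen-bond donor and acceptor, gives way to isopropyl, which has neither, and the read-out at this one dose does not separate the two compounds. No measurement here gives a reason for this outcome at this position.

On these data alone, what remains open is whether any group on this saturated chain carbon can move the read-out beyond the scatter. A free primary amine or a longer unbranched chain such as hexyl would test this on the same core.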